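Fluoro on the pyridine ring of a cyclic urea series

This account rests on a few compounds, and the source may have more. Where it says the series, first, only, none or still open, it means among the compounds named here.

Going by the values given here, compound 2 `C[C@@H]1CN(Cc2ccccc2)c2ncccc2[C@H](C)N1C(=O)NCc1ccccc1` gives the lower of the two numbers so far: in an assay on HEK293 cells for inhibition of Voltage-dependent T-type calcium channel subunit alpha-1G (Homo sapiens), read by FLIPR and calcium flux, with a stated time of 3 min (on this read-out lower numbers stand for stronger inhibition and higher numbers for weaker inhibition), compound 2 gives 15 nM, while compound 1 `C[C@@H]1CN(Cc2ccccc2)c2nc(C(F)(F)F)ccc2[C@H](C)N1C(=O)NCc1ccccc1` gives 57 nM. Among the compounds with values here, the only step measured, a 3.8-fold lower number from compound 1 to compound 2 (0.58 log units; beyond the scatter), shows that removing a trifluoromethyl lowered the number modestly. Compound 3 `C[C@@H]1CN(Cc2ccccc2)c2ncc(F)cc2[C@H](C)N1C(=O)NCc1ccccc1` differs from compound 2 by fluoro in place of hydrogen on an aromatic carbon. A single fluoro at a different place than the trifluoromethyl is a much smaller change, so only a small shift, if any beyond the scatter, is expected, a 1.5-fold higher number from compound 2 to compound 3 (0.17 log units; within the scatter). For compound 3 the estimate in this assay is 22 nM, within 8 nM to 60 nM.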

Compound 3, half-maximal inhibitory concentration: 65 nM
Estimate against measurement, compound 3: 3.0-fold (0.47 log units) below, and the stated range ends below it.
By their numbers in this assay, from the lowest: compound 2; then compounds 1 and 3 (each within the scatter of the next).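

At this position, two atoms from the ring nitrogen and para to a fused ring, a single fluoro in place of hydrogen is not a silent change: it gives a 4.3-fold higher number from compound 2 to compound 3 (0.64 log units; beyond the scatter). Compound 2, with hydrogen here, thus stays below both substituted compounds by more than the scatter, so the earlier loss on adding trifluoromethyl at another ring carbon is no longer the only case. Nothing measured here accounts for this shift. On these data alone, whether chloro, methoxy or an amine at this position would raise the number as well remains open.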